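Removing a Fluoro Group in a Weakly Cytotoxic Series

The source may report more compounds than this note shows. Statements on the series, on what has been measured and on what is new or still open speak of the compounds shown alone.

Compound 2 `Nc1nc(N)c(CCCNc2cc(F)cc(F)c2[N+](=O)[O-])c(O)n1` is a difluoro nitroaryl compound that gives 97000 nM in a functional assay on CCRF-CEM cells (Homo sapiens) for cytotoxicity, in the absence of a further agent; a higher number here means a weaker inhibitor, a lower number a stronger inhibitor. Compound 1 `Nc1nc(N)c(CCCNc2cc(F)ccc2[N+](=O)[O-])c(O)n1` carries hydrogen in place of one fluoro. In this assay compound 1 reaches only the limit of the assay, > 100000 nM, which is not a number. The measured step is an at least 1.0-fold higher number from compound 2 to compound 1 (0.01 log units; that floor lies within the scatter), with hydrogen in place of fluoro on an aromatic carbon.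

Compound 3 `Nc1nc(N)c(CCCN(Cc2ccc(NC(CCC(=O)O)C(=O)O)cc2)c2cc(F)cc(F)c2[N+](=O)[O-])c(O)n1` differs from compound 2 in a larger part of the molecule, and that difference between the two cores is not broken down here. In this assay compound 3 also sits at the limit, > 100000 nM, which is not a number.

Compound 4 `Nc1nc(N)c(CCCN(Cc2ccc(NC(CCC(=O)O)C(=O)O)cc2)c2cc(F)ccc2[N+](=O)[O-])c(O)n1` has not yet been measured. It stands to compound 3 as compound 1 stands to compound 2, by hydrogen in place of fluoro on an aromatic carbon; the two place lines read the same, so this is the same change. Its size is expected to be a step that the limit leaves unreadable from compound 3 to compound 4, because an at least 1.0-fold higher number from compound 2 to compound 1 (0.01 log units; that floor lies within the scatter) gave no gain and because the limit of > 100000 nM in this assay, at which 2 of the 3 values shown sit, leaves little room for a number at all. Compound 4 is estimated at 150000 nM.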

Compound 4, half-maximal inhibitory concentration: > 100000 nM
Compound 4: no number, only a limit (the forecaster's own chance of this, stated with the estimate: 85%); the middle value lies beyond the limit too.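

Compound 3 and compound 4 both stand at a limit in this assay and not at a number, so no step can be read between them: the limit of > 100000 nM in this assay, at which 3 of the 4 values shown sit.

The compounds shown leave open how strong compound 1, compound 3 and compound 4 really are, and whether hydrogen in place of fluoro changes cytotoxicity in either core.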